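This account rests on a few compounds, and the source may have more. Where it says the series, first, only, none or still open, it means among the compounds named here.

Measured compounds:
Compound 1, `CCCCCCCC/C=C\CCCCCCCCNC(=O)Nc1ccc(OC)cc1OC`, gives 5400 nM in an assay on microsomes from intestinal mucosa for inhibition of acyl-CoA:cholesterol acyltransferase (Oryctolagus cuniculus); on this read-out higher numbers stand for weaker inhibition and lower numbers for stronger inhibition.
Compound 2, `CCCCCCCC/C=C\CCCCCCCCNC(=O)Nc1cc(C)ccc1C`, gives 4500 nM in this assay.

Compound 2 and compound 1 sit within the scatter of each other: the step of a 1.2-fold lower number from compound 1 to compound 2 (0.08 log units; within the scatter) is too small to separate them on this read-out, so compound 2 cannot be called more or less potent than compound 1.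

Compound 3, `CCCCCCCC/C=C\CCCCCCCCNC(=O)Nc1c(C)cccc1Cl`, has not yet been measured in this assay. It differs from compound 2 in one place: 2-chloro-6-methylphenyl in place of 2,5-dimethylphenyl on an amide-type nitrogen. Within the data shown here, only one measured step bears on an exchange of the substituted phenyl on that nitrogen, namely a 1.2-fold lower number from compound 1 to compound 2 (0.08 log units; within the scatter), which swapped one substituted phenyl for another without moving the number beyond the scatter. The change from compound 2 to compound 3 is an exchange of the same kind, between two substituted phenyls with no donors or acceptors on either side. Nothing measured argues for a shift in either direction, so the step of no change at the digits printed from compound 2 to compound 3 (within the scatter) is expected to stay within the scatter. Compound 3 is therefore estimated at 4500 nM in this assay, with a range from 1500 nM to 13000 nM.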

Compound 3, half-maximal inhibitory concentration: 180 nM
Beside the measured number, compound 3's estimate is 25-fold (1.40 log units) above it; measured number outside the range, below it.
By their numbers in this assay, from the lowest: compound 3; then compounds 2 and 1 (each within the scatter of the next).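

The substituted phenyl on the amide-type nitrogen proved to be a position that can move the number strongly in this assay, which the earlier exchange, confined to the scatter, had not revealed. Replacing 2,5-dimethylphenyl with 2-chloro-6-methylphenyl gives a 25-fold lower number from compound 2 to compound 3 (1.40 log units; beyond the scatter) and replacing the phenyl of compound 1 gives a 30-fold lower number from compound 1 to compound 3 (1.48 log units; beyond the scatter) so compound 3 stands as the strongest inhibitor of the three on this read-out. The step from compound 2 to compound 3 leaves the counts of heavy atoms, hydrogen-bond donors and hydrogen-bond acceptors in the group unchanged, so those counts do not account for it, and no measurement bears on why the number falls so far.

The compounds shown leave open whether the drop follows the chlorine itself or the different arrangement of the two groups on the phenyl, a question that a bromine or a methyl in place of that chlorine would bear on. They also leave open whether the same drop would hold with a shorter or fully saturated chain in place of the long unsaturated chain they all share.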